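The source may hold more compounds than are shown below. What is called first, only, known or untested is meant among the compounds shown, and "the series" means these compounds.

Working notes on a small set of oxazole carboxamides tested in a functional assay on A549 cells (Homo sapiens) for inhibition, read by MTT assay, with a stated time of 72 h; a higher number here means a weaker inhibitor, a lower number a stronger inhibitor.

Compound 1 `Cc1nc(-c2ccc(F)cc2)c(C(=O)N2CCN(c3cc(Cl)cc(Cl)c3)CC2)o1` gives 296 nM in this assay. Compound 2 `COc1cc(OC)cc(N2CCN(C(=O)c3oc(C)nc3-c3ccc(F)cc3)CC2)c1` carries a 3,5-dimethoxyphenyl in place of the 3,5-dichlorophenyl on the amine nitrogen in the ring, the counted difference being (3,5-dimethoxyphenyl in place of 3,5-dichlorophenyl on an amine nitrogen in a ring); in this assay compound 2 gives 158 nM. The step of a 1.9-fold lower number from compound 1 to compound 2 (0.27 log units; within the scatter) lies within the scatter. Compound 3 `Cc1nc(-c2cccc(F)c2)c(C(=O)N2CCN(c3cc(Cl)cc(Cl)c3)CC2)o1` differs from compound 1 only in the core, the two having the same atoms joined differently, as counted in 3-fluorophenyl in place of 4-fluorophenyl on an aromatic carbon; in this assay compound 3 gives 354 nM. The step of a 1.2-fold higher number from compound 1 to compound 3 (0.08 log units; within the scatter) is within the scatter as well, so compounds 1 and 3 are not told apart here, while compound 3 and compound 2 differ by a gap beyond the scatter.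

Compound 4 `COc1cc(OC)cc(N2CCN(C(=O)c3oc(C)nc3-c3cccc(F)c3)CC2)c1` has not yet been measured in this assay. It arises from compound 3 by the change (3,5-dimethoxyphenyl in place of 3,5-dichlorophenyl on an amine nitrogen in a ring), which is the same change, at the same place, as that from compound 1 to compound 2; among the compounds shown it occurs twice in all. Going by the values given here, with only the pair compound 1 to compound 2 as precedent, and that step within the scatter, the step from compound 3 to compound 4 is expected to be of similar size, a 1.9-fold lower number from compound 3 to compound 4 (0.27 log units; within the scatter), resting on a 1.9-fold lower number from compound 1 to compound 2 (0.27 log units; within the scatter). On that basis compound 4 is estimated to give about 190 nM in this assay, with a plausible range from 90 nM to 420 nM.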

Compound 4, half-maximal inhibitory concentration: 98 nM
For compound 4 the middle estimate is 1.9-fold (0.29 log units) above the measured one; the range from low to high includes it.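

In this assay, the 3,5-dimethoxyphenyl in place of the 3,5-dichlorophenyl on the amine nitrogen in the ring gives a 3.6-fold lower number from compound 3 to compound 4 (0.56 log units; beyond the scatter), and set beside the earlier step, the change carries from one core to the other without a gap that can be told apart: the same change on two cores in this assay, a 1.9-fold lower number (0.27 log units; within the scatter) from compound 1 to compound 2 and a 3.6-fold lower number (0.56 log units; beyond the scatter) from compound 3 to compound 4, 1.9-fold (0.29 log units) apart, within the scatter of two such steps. The 3-fluorophenyl in place of the 4-fluorophenyl, read on the pair with the 3,5-dimethoxyphenyl, gives a 1.6-fold lower number from compound 2 to compound 4 (0.21 log units; within the scatter), and this change likewise shows no gap between its two settings: the same change on two cores in this assay, a 1.2-fold higher number (0.08 log units; within the scatter) from compound 1 to compound 3 and a 1.6-fold lower number (0.21 log units; within the scatter) from compound 2 to compound 4, 1.9-fold (0.29 log units) apart, within the scatter of two such steps. The step to the 3,5-dimethoxyphenyl lies beyond the scatter only on the core of compound 3, and two pairs fix neither a size for this change nor its behaviour on any core outside these four compounds.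

The compounds shown leave open whether the step holds when the two methoxy groups give way to an amine, a carboxylic acid or a single methoxy on that phenyl. They also leave open how either step would read with a chlorine in place of the fluorine on the other phenyl, and in any read-out other than this one.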